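A few compounds are considered here, and "the series" means these few. Any claim that something is new, unique, unknown or untested is made for them only; others in the source may bear on it.

Measured so far in a functional assay on DU-145 cells (Homo sapiens) for inhibition, read by trypan blue exclusion, with a stated time of 96 h; a higher number here means a weaker inhibitor of growth, a lower number a stronger inhibitor of growth:
compound 1 `O=C(/C(=C\c1ccccc1F)S(=O)(=O)c1ccc(Br)cc1)c1ccc(Cl)cc1`, 25000 nM;
compound 2 `COc1ccc(/C=C(\C(=O)c2ccc(Cl)cc2)S(=O)(=O)c2ccc(Br)cc2)cc1`, 10000 nM.
Compound 3 `Cc1ccc(S/C(=C/c2c(O)cc(O)cc2O)C(=O)c2ccc(Cl)cc2)cc1` gives no number, only a limit, > 100000 nM, which is the limit of > 100000 nM in this assay, at which 1 of the 3 values shown sits.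

Compound 3 thus sits at the weak end of what is shown, without a measurable value. Compound 4 `O=C(/C(=C\c1c(O)cc(O)cc1O)S(=O)(=O)c1ccc(Br)cc1)c1ccc(Cl)cc1` differs from it in one place: (4-bromophenyl)sulfonyl in place of (4-methylphenyl)sulfanyl on a double-bonded chain carbon bound to a carbonyl carbon and a double-bonded chain carbon. Among the measured compounds shown here, none of the measured steps bears on this change. For the measured compounds named here, the one measured step, a 2.5-fold lower number from compound 1 to compound 2 (0.40 log units; beyond the scatter), concerns the aryl on the other chain carbon, and compound 1 and compound 2 both already carry the entering group while giving measurable values. The expectation in this assay is therefore a move to a measurable number, toward a lower value, with the expected step being an at least 3.3-fold lower number from compound 3 to compound 4 (0.52 log units; beyond the scatter). Compound 4 is expected at 30000 nM, in a range from 6000 nM to 100000 nM.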

Compound 4, concentration for 50% growth inhibition: > 100000 nM
Compound 4: only a limit was reported; the forecaster's own chance of this, stated with the estimate: 35%; middle value at least 3.3-fold (0.52 log units) from the limit.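

In this assay, the (4-bromophenyl)sulfonyl group does not keep a measurable value when 2,4,6-trihydroxyphenyl is present, and that aryl change reads as a clear loss: an at least 10-fold higher number from compound 2 to compound 4 (1.00 log units; beyond the scatter) and an at least 4.0-fold higher number from compound 1 to compound 4 (0.60 log units; beyond the scatter). Compound 4 gives only a limit, and the step from compound 3 to it cannot be read: the limit of > 100000 nM in this assay, at which 2 of the 4 values shown sit.

Among the compounds shown here, whether (4-bromophenyl)sulfonyl and (4-methylphenyl)sulfanyl differ at this position remains open, as no pair with two measurable values compares them. Also open, from the compounds shown here alone, is how an amine in place of the 2,4,6-trihydroxyphenyl would read.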